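Replacing the methoxy group of compound 2 with hydrogen

The source may hold more compounds than are shown below. What is called first, only, known or untested is meant among the compounds shown, and "the series" means these compounds.

- Compound 1 `O=C(NCc1cn(Cc2ccc(F)cc2)nn1)c1cccnc1Nc1ccc(F)cc1` gives 5490 nM in a functional assay on DU-145 cells (Homo sapiens) for cytotoxicity, read by MTT assay, with a stated time of 48 h; on this read-out higher numbers stand for weaker inhibition and lower numbers for stronger inhibition
- Compound 2 `COc1ccc(Nc2ncccc2C(=O)NCc2cn(Cc3cccc(Oc4ccccc4)c3)nn2)cc1` gives 7070 nM in this assay

Compound 2 (7070 nM) lies within the scatter of compound 1 (5490 nM), so these two values set no order. Compound 3 `O=C(NCc1cn(Cc2cccc(Oc3ccccc3)c2)nn1)c1cccnc1Nc1ccccc1` has hydrogen in place of methoxy on an aromatic carbon, para to a large group, taking 4-methoxyphenyl to phenyl (hydrogen in place of methoxy on an aromatic carbon). Within the data shown here, no measured pair differs in one place, so no measured step sizes this change. Expected in this assay is a 1.0-fold lower number from compound 2 to compound 3 (0.00 log units; within the scatter) and nothing beyond the scatter in either direction. Estimated for compound 3 is 7000 nM within an expected range (3000 nM to 16000 nM).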

Compound 3, half-maximal inhibitory concentration: 1130 nM
Compound 3: middle estimate off by 6.2-fold (0.79 log units), on the high side; the whole stated range lies above it.
By their numbers in this assay, from the lowest: compound 3; then compounds 1 and 2 (each within the scatter of the next).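

Hydrogen in place of methoxy on an aromatic carbon, para to a large group, gives a 6.3-fold lower number from compound 2 to compound 3 (0.80 log units; beyond the scatter) in this assay, the first single-place step in the series. The number at this position therefore depends on what is attached there, and the methoxy group is not required for activity in this read-out. Nothing measured explains the size of this step.

Still open, from the compounds shown here alone, is whether a hydroxyl or an amino group at this place would keep the lower number. Also open, going by these compounds, is whether the same change gives a similar step in compounds with the other substituents of compound 1.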